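Hydroxymethylbenzyl isomer swap carried across two cores

The source may report more compounds than this note shows. Statements on the series, on what has been measured and on what is new or still open speak of the compounds shown alone.

Compound 1 `Cc1c(C)c2ccc(OCC3CCCN(Cc4ccc(CO)cc4)C3)cc2oc1=O` gives 1100 nM in an assay for inhibition of Amine oxidase [flavin-containing] A (Homo sapiens), read by fluorescence, using microsomes, with a stated time of 30 min; a lower number here means a stronger inhibitor, a higher number a weaker inhibitor. Compound 2 `Cc1c(C)c2ccc(OCC3CCCN(Cc4cccc(CO)c4)C3)cc2oc1=O` carries 3-(hydroxymethyl)phenyl in place of 4-(hydroxymethyl)phenyl on a saturated chain carbon bound to an amine nitrogen in a ring and in this assay compound 2 gives 2200 nM; the step of a 2.0-fold higher number from compound 1 to compound 2 (0.30 log units; within the scatter) lies within the scatter. Compound 3 `Cc1cc(=O)oc2cc(OCC3CCN(Cc4ccc(CO)cc4)CC3)ccc12` is built on a different core, and the difference between the two cores is not broken down here. In this assay compound 3 gives 11000 nM, the highest of the three numbers. Compound 4 `Cc1cc(=O)oc2cc(OCC3CCN(Cc4cccc(CO)c4)CC3)ccc12` is not yet measured; it differs from compound 3 by 3-(hydroxymethyl)phenyl in place of 4-(hydroxymethyl)phenyl on a saturated chain carbon bound to an amine nitrogen in a ring, the same change as in the earlier pair. Within the data shown here, the expected step of a 2.0-fold higher number from compound 3 to compound 4 (0.30 log units; within the scatter) is set beside the measured one and rests on the single precedent a 2.0-fold higher number from compound 1 to compound 2 (0.30 log units; within the scatter), a small move. On that basis compound 4 is estimated at 22000 nM in this assay, with an expected range from 8000 nM to 60000 nM.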

Compound 4, half-maximal inhibitory concentration: 3500 nM
Compound 4: the middle estimate sits 6.3-fold (0.80 log units) above what was measured, and the stated range ends above it.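

In this assay, 3-(hydroxymethyl)phenyl in place of 4-(hydroxymethyl)phenyl gives a 3.1-fold lower number from compound 3 to compound 4 (0.50 log units; beyond the scatter), a real gain on this core, and the step on the first core does not carry over to this one: the same change on two cores in this assay, a 2.0-fold higher number (0.30 log units; within the scatter) from compound 1 to compound 2 and a 3.1-fold lower number (0.50 log units; beyond the scatter) from compound 3 to compound 4, 6.3-fold (0.80 log units) apart, beyond the scatter of two such steps

In this series, then, the step measured on one core is no reliable guide to the direction or size of the step on the other. With a single pair on each core, this does not show how the change would behave on any further core.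

The compounds shown leave open which part of the difference between the two cores sets the step. Also open, going by these compounds, is how a carboxylic acid or a primary amine in place of the hydroxymethyl group would read in this assay on either core.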